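Amide nitrogen substitution and cytotoxicity in this series

A few compounds are considered here, and "the series" means these few. Any claim that something is new, unique, unknown or untested is made for them only; others in the source may bear on it.

Compound 1 `NC(=O)c1sc2nc(-c3ccccc3)cc(C(F)(F)F)c2c1N` carries an unsubstituted carboxamide. In an ADME assay on Huh-7 cells (Homo sapiens) for cytotoxicity, read by MTT assay, with a stated time of 72 h (on this read-out lower numbers stand for higher toxicity in this test and higher numbers for lower toxicity in this test), compound 1 gives > 20000 nM, which is a limit of the assay rather than a number. Compound 2 `Nc1c(C(=O)NCc2cccs2)oc2nc(-c3ccccc3)cc(C(F)(F)F)c12` gives > 20000 nM in this assay, again only a limit. Compound 3 `Nc1c(C(=O)N2CCCCC2)sc2nc(-c3ccccc3)cc(C(F)(F)F)c12` gives > 20000 nM in this assay, likewise a limit. For the measured compounds named here, the single-place change from compound 1 to compound 3 therefore reads a step that the two limits leave unreadable from compound 1 to compound 3, and the only evidence the set offers is the limit of > 20000 nM in this assay, at which 3 of the 3 values shown sit. Compound 4 `Nc1c(C(=O)NCc2cccs2)sc2nc(-c3ccccc3)cc(C(F)(F)F)c12` differs from compound 1 by (thiophen-2-yl)methyl in place of hydrogen on an amide-type nitrogen. Going by the values given here, no measured step fixes the size of this change; all three values sit at the limit. Compound 4 is thus expected at 30000 nM in this assay, within 15000 nM to 100000 nM, most probably reported as a limit once more. The expected step from compound 1 to compound 4 is a step that the limit leaves unreadable from compound 1 to compound 4.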

Compound 4, half-maximal cytotoxic concentration: > 20000 nM
Compound 4: a limit, no number; the forecaster's own chance of this, stated with the estimate: 80%; the middle value does not contradict the limit.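

For the compounds shown here, compound 1, compound 3 and compound 4 all sit at a limit in this assay, so no step among them can be read. The compounds shown leave open whether their amide substituents differ in cytotoxicity at all: the limit of > 20000 nM in this assay, at which 4 of the 4 values shown sit.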